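Solubility at low pH: sulfoxide in place of hydroxypiperidine amide

A few compounds are considered here, and "the series" means these few. Any claim that something is new, unique, unknown or untested is made for them only; others in the source may bear on it.

Measured so far:
- compound 1, `CS(=O)(=O)c1cncc(-c2ccc3ncc(-c4ccc(S(=O)(=O)C5CC5)cc4)n3n2)c1`: < 5000 nM
- compound 2, `CS(=O)(=O)c1ccc(-c2cnc3ccc(-c4cccc(C(=O)N5CCC(O)CC5)c4)nn23)cc1`: > 200000 nM
- compound 3, `CS(=O)(=O)c1ccc(-c2cnc3ccc(-c4ccnc(C(F)(F)F)c4)nn23)cc1`: 5400 nM

In a physicochemical assay for solubility, at pH 2 (on this read-out higher numbers stand for higher solubility and lower numbers for lower solubility), compound 2 gives > 200000 nM, which is a limit of the assay and not a number; it sits at the limit of > 200000 nM in this assay, at which 1 of the 3 values shown sits. Compound 1 also returns only a limit in this assay, at the limit of < 5000 nM in this assay, at which 1 of the 3 values shown sits. Among the measured compounds shown here, compound 3 is the one compound of the three with a numeric value in this assay, namely 5400 nM. Compound 2 thus stands at the upper end of what this assay reports, while compound 1 stands at the lower end, and the gap between the two is wide.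

Compound 4, `C[S+]([O-])c1cccc(-c2ccc3ncc(-c4ccc(S(C)(=O)=O)cc4)n3n2)c1`, is not yet measured. It differs from compound 2 by a group of 3 heavy atoms (1 carbon, 1 oxygen, 1 sulfur; no ring) in place of a group of 9 heavy atoms (6 carbon, 1 nitrogen, 2 oxygen; one six-membered non-aromatic ring with 1 hetero atom), on an aromatic carbon, a methylsulfinyl group meta to a large group where compound 2 carries the (4-hydroxypiperidin-1-yl)carbonyl group. For the measured compounds named here, no measured pair in the set isolates this change, so the size of the step is unknown. With the hydrogen-bond donor of compound 2 gone, a step downward in this assay that is beyond the scatter is expected, though compound 4 is expected to remain above the level of compound 1. The expected step of an at least 10-fold lower number from compound 2 to compound 4 (1.00 log units; beyond the scatter) leads to an estimate for compound 4 of 20000 nM, with a range from 4000 nM to 100000 nM.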

Compound 4, solubility: 188000 nM
Compound 4: the middle estimate sits 9.4-fold (0.97 log units) below what was measured; measured number outside the range, above it.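

In this assay compound 2 returns only a limit: the limit of > 200000 nM in this assay, at which 1 of the 4 values shown sits. Read against that limit, the change gives an at least 1.0-fold lower number from compound 2 to compound 4 (0.02 log units; that floor lies within the scatter), so the methylsulfinyl group in place of the (4-hydroxypiperidin-1-yl)carbonyl group on this aromatic carbon shows no drop that can be told from the scatter, although a larger true drop stays possible. The entering group has no ring and no hydrogen-bond donor, yet compound 4 gives 188000 nM, a number and not a limit, so neither the ring nor the donor of the amide is needed for a reading at this level on this core.

From the compounds shown here alone, the true size of the step stays open, since one end of it is a limit. Also open, going by these compounds, is whether the sulfur matters here, or whether a methoxy group or a primary amine at this place would read the same.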